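Benzyl for Phenyl: A Small Change on the Ring

A few compounds are considered here, and "the series" means these few. Any claim that something is new, unique, unknown or untested is made for them only; others in the source may bear on it.

Compound 1, `O=C1NC(O)(CCn2cc(-c3ccccc3)nn2)C(OCc2ccccc2)=C1OCc1ccccc1`, was tested in a functional assay on HCT-116 cells (Homo sapiens) for antiproliferative activity, read by MTT assay, with a stated time of 24 h (on this read-out lower numbers stand for stronger inhibition and higher numbers for weaker inhibition), where compound 1 gives 53400 nM. Within the data shown here, that is the only plain number in this set. Compound 2, `Cc1ccc(-c2cn(C/C=C3\OC(=O)C(OCc4ccccc4)=C3OCc3ccccc3)nn2)cc1`, was tested in the same way; compound 2 gives > 100000 nM, which is a limit of the assay rather than a measured number. Among the measured compounds shown here, compound 1 therefore stands as the one compound with a definite value, and no measured pair differs in a single place, so the size of any step has to be judged from the structures alone.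

Compound 3, `O=C1NC(O)(CCn2cc(Cc3ccccc3)nn2)C(OCc2ccccc2)=C1OCc1ccccc1`, keeps the core of compound 1 and alters only the group on the five-membered aromatic ring with 3 nitrogen: benzyl in place of phenyl on an aromatic carbon. For the measured compounds named here, with no measured step to lean on, the change expected in this assay is a 1.1-fold higher number from compound 1 to compound 3 (0.05 log units; within the scatter), a step that should stay within the usual scatter, with no clear direction. Compound 3 is accordingly expected to give about 60000 nM, with a likely range from 25000 nM to 150000 nM.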

Compound 3, half-maximal inhibitory concentration: 51200 nM
Compound 3: middle estimate off by 1.2-fold (0.07 log units), on the high side; low and high end bracket the measured number.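

In this assay, among these compounds, benzyl in place of phenyl on the aromatic carbon gives a 1.0-fold lower number from compound 1 to compound 3 (0.02 log units; within the scatter), and this is the first step in the set that can be read from two measured compounds. Both groups carry one six-membered aromatic ring of carbon only, so the pair tests the change from a ring set directly on the five-membered aromatic ring with 3 nitrogen to the same ring held through the benzyl carbon. On this read-out, that change leaves compound 1 and compound 3 within the usual scatter of each other, so at this position the assay does not tell phenyl and benzyl apart.

Compound 2 carries a limit of the assay rather than a number and differs from the others in more than one place, so no step to it can be read: the limit of > 100000 nM in this assay, at which 1 of the 3 values shown sits. The compounds shown also leave open how this position would respond to a group of another kind, such as an amine, a carboxylic acid or a longer chain of carbon in place of benzyl.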